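A few compounds are considered here, and "the series" means these few. Any claim that something is new, unique, unknown or untested is made for them only; others in the source may bear on it.

Measured so far:
- compound 1, `O=C(CCCCC#Cc1cccnc1)c1ncc(-c2ccccn2)o1`: 300 nM
- compound 2, `O=C(CCCCCCc1ccccc1C(=O)O)c1ncc(-c2ccccn2)o1`: a limit, > 600 nM
- compound 3, `O=C(CCCCCCc1ccccn1)c1ncc(-c2ccccn2)o1`: 120 nM

In an assay for inhibition of Fatty-acid amide hydrolase 1 (Rattus norvegicus) (on this read-out lower numbers stand for stronger inhibition and higher numbers for weaker inhibition), compound 3 gives 120 nM, the lowest of the two numbers reported; compound 1 sits at 300 nM, the step being a 2.5-fold lower number from compound 1 to compound 3 (0.40 log units; beyond the scatter). Compound 2 returned only a limit in this assay, > 600 nM, so its step to compound 3 is an at least 5.0-fold lower number from compound 2 to compound 3 (0.69 log units; beyond the scatter).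

Compound 4, `O=C(O)c1cccc(CCCCCCC(=O)c2ncc(-c3ccccn3)o2)c1`, differs from compound 3 by the change (3-carboxyphenyl in place of pyridin-2-yl on a saturated chain carbon, six bonds along the chain from a carbonyl carbon). The step that bears on it most directly is an at least 5.0-fold lower number from compound 2 to compound 3 (0.69 log units; beyond the scatter), where a carboxyphenyl group in that same place fell at the limit (the limit of > 600 nM in this assay, at which 1 of the 3 values shown sits); the other step, a 2.5-fold lower number from compound 1 to compound 3 (0.40 log units; beyond the scatter), concerns a different linker and is only loosely related.

Compound 4 is therefore expected to give a higher number than compound 3 in this assay, with a step of about a 6.7-fold higher number from compound 3 to compound 4 (0.82 log units; beyond the scatter) anticipated, and a fair chance that only a limit is reported. The estimate for compound 4 is 800 nM, in a range from 250 nM to 3000 nM.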

Compound 4, inhibition constant: > 600 nM
Compound 4 ended at the assay's limit (the forecaster's own chance of this, stated with the estimate: 50%); the middle value does not contradict the limit.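

With 3-carboxyphenyl in place of pyridin-2-yl on a saturated chain carbon, six bonds along the chain from a carbonyl carbon, this assay gives an at least 5.0-fold higher number from compound 3 to compound 4 (0.69 log units; beyond the scatter), so the loss seen with 2-carboxyphenyl in compound 2 is not confined to that one carboxyphenyl group. Compound 2 and compound 4 both stand at a limit, the step between them cannot be read, and the two carboxyphenyl groups therefore cannot be put in order. Both carboxyphenyl compounds now sit at the same limit: the limit of > 600 nM in this assay, at which 2 of the 4 values shown sit.

On these data alone, how far either compound lies beyond that limit remains unknown. The compounds shown also leave open whether a methyl ester or a primary amide in place of the carboxylic acid, or a 4-carboxyphenyl group at this place, would return a measurable number.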